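A few compounds are considered here, and "the series" means these few. Any claim that something is new, unique, unknown or untested is made for them only; others in the source may bear on it.

In a functional assay on QGY-7703 cells (Homo sapiens) for cytotoxicity, read by MTT assay, with a stated time of 24 h (a higher number here means a weaker inhibitor, a lower number a stronger inhibitor), compound 1 `CN1C/C(=C\c2cccnc2)C(=O)/C(=C/c2ccccc2F)C1` gives 4470 nM and compound 3 `Cc1ccc(S(=O)(=O)N2C/C(=C\c3cccnc3)C(=O)/C(=C/c3ccccc3F)C2)cc1` gives 9700 nM, the higher of these two numbers. Compound 2 `CN1C/C(=C\c2ccc(C#N)cc2)C(=O)/C(=C/c2cccnc2)C1` reaches only a limit, > 20000 nM. Compound 4 `CC(=O)Nc1ccc(S(=O)(=O)N2C/C(=C\c3cccnc3)C(=O)/C(=C/c3ccccc3F)C2)cc1` keeps the frame of compound 3 and carries one change, acetamido in place of methyl on an aromatic carbon, para to a large group. The nearest evidence is the modest 2.2-fold higher number from compound 1 to compound 3 (0.34 log units; beyond the scatter), where (4-methylphenyl)sulfonyl replaced methyl on the ring amine nitrogen. For the measured compounds named here, the larger at least 4.4-fold higher number from compound 1 to compound 2 (0.65 log units; beyond the scatter) arose at a different place, and no measured step tests this one directly. No shift beyond the scatter is therefore expected in this assay, and the estimated change is a 1.2-fold lower number from compound 3 to compound 4 (0.08 log units; within the scatter). For compound 4 the expected value is 8000 nM, within an estimated range of 2800 nM to 20000 nM.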

Compound 4, half-maximal inhibitory concentration: 9640 nM
For compound 4 the middle estimate is 1.2-fold (0.08 log units) below the measured one; the measured number falls inside the stated range.
By their numbers in this assay, from the lowest: compound 1; then compounds 4 and 3 (each within the scatter of the next). At a limit, above all of these: compound 2.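

In this assay, the first step shown at this position, acetamido in place of methyl on an aromatic carbon, para to a large group, gives a 1.0-fold lower number from compound 3 to compound 4 (0.00 log units; within the scatter). Going from 4-methylphenyl to 4-acetamidophenyl thus adds a hydrogen-bond donor and acceptor here with no shift beyond the scatter. No measurement shown here accounts for this result.

On these data alone, whether an amine, a carboxylic acid or a longer chain at this aromatic carbon would behave the same stays open. So does whether a group at another ring position would.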